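This account rests on a few compounds, and the source may have more. Where it says the series, first, only, none or still open, it means among the compounds named here.

In an assay on isolated protein for displacement of a labelled ligand from prostaglandin E2 receptor EP3 subtype (Homo sapiens), read by scintillation counting, with a stated time of 2 h (a lower number here means a stronger inhibitor, a higher number a weaker inhibitor), compound 1 `Cc1nc(C)c(S(=O)(=O)NC(=O)NC/C=C2\CCCc3cnn(Cc4ccc(Cl)cc4Cl)c32)s1` gives 2 nM, compound 2 `Cn1cc(S(=O)(=O)NC(=O)NC/C=C2\CCCc3cnn(Cc4ccc(Cl)cc4Cl)c32)cn1` gives 9 nM, and compound 3 `O=C(NC/C(F)=C1\CCCc2cnn(C3CCN(c4ccc(F)cc4)CC3)c21)NS(=O)(=O)c1cc(Cl)c(Cl)s1` gives 13 nM. Compound 2 thus holds the second highest of the three numbers; its gap to compound 3 lies within the scatter, while the step of a 4.5-fold higher number from compound 1 to compound 2 (0.65 log units; beyond the scatter) lies beyond it. Compound 4 `O=C(NC/C=C1\CCCc2cnn(Cc3ccc(Cl)cc3Cl)c21)NS(=O)(=O)c1cc(Cl)c(Cl)s1` has not been measured in this assay. It differs from compound 2 in one place: 4,5-dichlorothiophen-2-yl in place of 1-methyl-1H-pyrazol-4-yl on a sulfonyl sulfur. Going by the values given here, only one measured step changes the group on the sulfonyl sulfur, namely a 4.5-fold higher number from compound 1 to compound 2 (0.65 log units; beyond the scatter), which shows that this position can move the number by a modest amount. Compound 3 carries the same (4,5-dichlorothiophen-2-yl)sulfonyl as compound 4 but differs from compound 2 elsewhere too, so its value serves only as a loose pointer. Because compound 1 gives 2 nM with a related five-membered heteroaryl on that sulfur, a somewhat lower number is anticipated for compound 4. The expected step is a 2.3-fold lower number from compound 2 to compound 4 (0.35 log units; beyond the scatter). The estimate for compound 4 in this assay is 4 nM, with a range from 1.5 nM to 12 nM.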

Compound 4, inhibition constant: 0.5 nM
For compound 4 the middle estimate is 8.0-fold (0.90 log units) above the measured one; measured number below the stated range.
By their numbers in this assay, from the lowest: compound 4; then compound 1; then compounds 2 and 3 (each within the scatter of the next).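

In this assay the group on the sulfonyl sulfur can move the number much further than the earlier step showed: 4,5-dichlorothiophen-2-yl in place of 1-methyl-1H-pyrazol-4-yl gives a large change, an 18-fold lower number from compound 2 to compound 4 (1.26 log units; beyond the scatter) and not merely a modest one. The same group also outdoes 2,4-dimethyl-1,3-thiazol-5-yl on the shared core, with a 4.0-fold lower number from compound 1 to compound 4 (0.60 log units; beyond the scatter) so the three groups on this sulfur now stand in an order whose every step lies beyond the scatter. Nothing available here accounts for this order.

What the compounds shown leave open is how a plain thiophen-2-yl without chlorine, or a phenyl, would read on this sulfonyl sulfur. Also open is whether the step carries over to the core of compound 3, which is shown only with the 4,5-dichlorothiophen-2-yl.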